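A few compounds are considered here, and "the series" means these few. Any claim that something is new, unique, unknown or untested is made for them only; others in the source may bear on it.

Measured so far: compound 1 `CN1CCC[C@H]1COc1cncc(O)c1` with 235 nM in an assay on HEK293 cells for displacement of a labelled ligand from Neuronal acetylcholine receptor; alpha3/beta4 (Homo sapiens), read by scintillation counting; on this read-out lower numbers stand for stronger inhibition and higher numbers for weaker inhibition; compound 2 `COc1ccc(O)cc1OC[C@@H]1CCCN1` with 7700 nM; compound 3 `COc1ccncc1OC[C@@H]1CCCN1` with 2900 nM.

Among these three, compound 2 stands at the highest number in this assay. Its nearest neighbour is compound 3, whose number is lower by a margin beyond the scatter, and the furthest is compound 1, whose number is lower still by a wide margin. Compound 2 is therefore the weakest binder of the three shown.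

The step under consideration leads from compound 2 to compound 4 `Oc1cccc(OC[C@@H]2CCCN2)c1`, which is yet to be measured in this assay. The change is hydrogen in place of methoxy on an aromatic carbon. Among the compounds with values here, no pair of measured compounds differs in exactly this way, so there is no measured step to lean on; what compound 2 and compound 3 show is only that the two differ by more than the scatter while both carry the methoxy.

Compound 4 is expected to land near compound 2, with at most a modest move and quite possibly none beyond the scatter: the estimated step is a 1.7-fold lower number from compound 2 to compound 4 (0.23 log units; within the scatter). For compound 4 the expected value is 4500 nM, with a range from 1300 nM to 15000 nM.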

Compound 4, inhibition constant: 3800 nM
The estimate for compound 4 lay 1.2-fold (0.07 log units) above the measured number; measured number inside the range.
By their numbers in this assay, from the lowest: compound 1; then compounds 3 and 4 (each within the scatter of the next); then compound 2.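

In this assay the piece now has its first direct reading of this position: putting hydrogen in place of methoxy on the aromatic carbon, ortho to a group of 7 heavy atoms and para to a hydroxy group, gives a 2.0-fold lower number from compound 2 to compound 4 (0.31 log units; beyond the scatter) and so moves the number modestly, though beyond the scatter. Within the data shown here, the methoxy at this place is therefore not required for the binding seen in this assay, since the compound without it, which also has 2 fewer heavy atoms, gives the lower number, and this could not be read from the earlier compounds, all of which differ in more than one place. Nothing shown here bears on why the number moves with this change.

This single step leaves open whether another group at the same aromatic carbon, such as a chlorine atom, an amine or a longer ethoxy chain, would take the number lower or higher than hydrogen or methoxy does. It also leaves open whether the same replacement would give a step of similar size on the core of compound 1 or compound 3.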